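The source may hold more compounds than are shown below. What is called first, only, known or untested is meant among the compounds shown, and "the series" means these compounds.

In a functional assay on MCF7 cells (Homo sapiens) for inhibition, read by MTT assay, with a stated time of 48 h (a higher number here means a weaker inhibitor of growth, a lower number a stronger inhibitor of growth), compound 1 (`COc1cc(C2=NN(C(=O)c3ccc(C)nc3)C(c3cn(C)c4ccccc34)C2)cc(OC)c1OC`) gives 180 nM. Compound 2 (`Cn1cc(C2CC(c3ccc(F)cc3)=NN2C(=O)c2cccnc2)c2cc(Br)ccc21`) gives 480 nM, the higher of the two numbers, and its gap to compound 1 lies beyond the scatter. For the measured compounds named here, these two compounds differ in more than one place, so the series offers no measured single-change step to calibrate the next one.

Compound 3 (`Cn1cc(C2CC(c3ccc(Br)cc3)=NN2C(=O)c2cccnc2)c2cc(Br)ccc21`) comes from compound 2 by one change: bromo in place of fluoro on an aromatic carbon. This is bromo in place of fluoro on an aromatic carbon, para to a large group, so 4-fluorophenyl becomes 4-bromophenyl. The rest of the structure stays the same.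

Going by the values given here, no measured pair shows this swap, so the anchor is compound 2 at 480 nM. The expectation in this assay is a small step, probably none beyond the scatter, with a slight lean towards a lower number. The expected change is a 1.2-fold lower number from compound 2 to compound 3 (0.08 log units; within the scatter). For compound 3 the estimated value is 400 nM, with an expected range of 170 nM to 950 nM.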

Compound 3, concentration for 50% growth inhibition: 11800 nM
Beside the measured number, compound 3's estimate is 30-fold (1.47 log units) below it; the whole stated range lies below it.
By their numbers in this assay, from the lowest: compound 1; then compound 2; then compound 3.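

In this assay, the series now has its first measured single-change step: a 25-fold higher number from compound 2 to compound 3 (1.39 log units; beyond the scatter) for the change from 4-fluorophenyl to 4-bromophenyl. The earlier pair differed in more than one place, so it could not isolate any one position, whereas here the rest of the structure stays the same and the whole gap belongs to this single swap on an aromatic carbon, para to a large group. This position is therefore not a neutral spot for exchanging one halogen for another, even though the swap replaces one heavy atom with one heavy atom and leaves the hydrogen-bond donor and acceptor counts and the net charge unchanged.

The compounds shown leave open whether chloro at this place would give a number close to that of compound 2 or to that of compound 3, whether a non-halogen group such as an amine or a nitrile would be tolerated there, and whether the same swap would have a comparable effect on the core of compound 1. No measurement among these compounds bears on why this swap produces so large a step.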